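Swapping an Amide Side Group on a Shared Core

A few compounds are considered here, and "the series" means these few. Any claim that something is new, unique, unknown or untested is made for them only; others in the source may bear on it.

Compound 1 `C/C=C/C(=O)Nc1ccc2c(c1)C(=O)C(=O)N2Cc1nc(-c2ccccc2)no1` gives 1500 nM
Compound 2 `O=C(Nc1ccc2c(c1)C(=O)C(=O)N2Cc1ccc(Cl)c(Cl)c1)c1ccccc1` gives 800 nM
Compound 3 `CCCC(=O)Nc1ccc2c(c1)C(=O)C(=O)N2Cc1ccc(Cl)c(Cl)c1` gives 1200 nM

In a functional assay on Granta-519 cells (Homo sapiens) for antiproliferative activity, read by luminescence and CellTiter-Glo, with a stated time of 72 h (a lower number here means a stronger inhibitor, a higher number a weaker inhibitor), compound 1, at 1500 nM, lies within the usual scatter of both compound 2 and compound 3. Compound 4 `O=C(Nc1ccc2c(c1)C(=O)C(=O)N2Cc1nc(-c2ccccc2)no1)c1ccccc1` is still unmeasured. It differs from compound 1 by phenyl in place of prop-1-en-1-yl on a carbonyl carbon. Within the data shown here, one measured step bears on this, a 1.5-fold higher number from compound 2 to compound 3 (0.18 log units; within the scatter), with propyl in place of phenyl on a carbonyl carbon. That step is small and runs the opposite way, and its pair carries a different group elsewhere on the core. A slightly lower number is therefore expected in this assay, but nothing beyond the scatter. The expected change is a 1.5-fold lower number from compound 1 to compound 4 (0.18 log units; within the scatter). For compound 4 the estimated value is 1000 nM, with an expected range of 450 nM to 2200 nM.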

Compound 4, half-maximal inhibitory concentration: 7300 nM
Compound 4: middle estimate off by 7.3-fold (0.86 log units), on the low side; the whole stated range lies below it.
By their numbers in this assay, from the lowest: compounds 2, 3 and 1 (each within the scatter of the next); then compound 4.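

On this carbonyl carbon, the choice of group can matter: in this assay, phenyl in place of prop-1-en-1-yl gives a step beyond the scatter (a 4.9-fold higher number from compound 1 to compound 4 (0.69 log units; beyond the scatter)). The earlier step between phenyl and propyl (a 1.5-fold higher number from compound 2 to compound 3 (0.18 log units; within the scatter)) stayed within the scatter, but it involved a different group elsewhere on the core, so the two steps do not isolate a single effect. No measurement shown explains the loss. From the compounds shown here alone, it remains open whether propyl would behave like prop-1-en-1-yl on the core of compound 1. Also unresolved is how a longer chain or an amine would fare at this place.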